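A few compounds are considered here, and "the series" means these few. Any claim that something is new, unique, unknown or untested is made for them only; others in the source may bear on it.

Measured so far in a functional assay on HL-60 cells (Homo sapiens) for cytotoxicity, read by WST assay, with a stated time of 48 h; a higher number here means a weaker inhibitor, a lower number a stronger inhibitor:

compound 1 `CCCCCC/C=C/C[C@H]1C[C@@H]([C@@H](O)c2ccccc2)CO[C@@H]1c1ccccc1`: 4990 nM
compound 2 `Oc1ccccc1/C=C/C[C@H]1C[C@@H]([C@@H](O)c2ccccc2)CO[C@@H]1c1ccccc1`: 10800 nM
compound 3 `COc1ccc(/C=C/C[C@H]2C[C@@H]([C@@H](O)c3ccccc3)CO[C@@H]2c2ccccc2)cc1`: 9010 nM

Compound 1 stands lowest of the three numbers in this assay; its nearest neighbour is compound 3, a gap within the scatter, and compound 2 is furthest, a gap beyond the scatter. Compounds 2 and 3 are within the scatter of each other, a 1.2-fold lower number from compound 2 to compound 3 (0.08 log units; within the scatter).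

Compound 4 `O[C@@H](c1ccccc1)[C@H]1CO[C@H](c2ccccc2)[C@@H](C/C=C/c2ccncc2)C1` differs from compound 1 at one place:
pyridin-4-yl in place of hexyl on a double-bonded chain carbon bound to a double-bonded chain carbon

Among the measured compounds shown here, the steps that bear on this are the two in which hexyl was exchanged for an aromatic ring at that place: a 2.2-fold higher number from compound 1 to compound 2 (0.34 log units; beyond the scatter) and a 1.8-fold higher number from compound 1 to compound 3 (0.26 log units; within the scatter). Both go upward, one just beyond and one just within the scatter. Pyridin-4-yl is a further aromatic ring entering where the hexyl leaves, so a step of the same modest size and the same direction is expected in this assay, a 1.8-fold higher number from compound 1 to compound 4 (0.26 log units; within the scatter). Compound 4 is therefore estimated at 9000 nM, with a range from 4000 nM to 20000 nM.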

Compound 4, half-maximal inhibitory concentration: > 100000 nM
Compound 4: no number, only a limit; the forecaster's own chance of this, stated with the estimate: 10%; middle value at least 11-fold (1.04 log units) away from the limit.
By their numbers in this assay, from the lowest: compounds 1, 3 and 2 (each within the scatter of the next, the first and the last beyond it). At a limit, above all of these: compound 4.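

Compound 4 has only a limit in this assay, not a number: the limit of > 100000 nM in this assay, at which 1 of the 4 values shown sits.

The earlier compounds shown here suggested that an aromatic ring at this place on the double-bonded chain carbon mattered little, yet pyridin-4-yl stands apart, with an at least 20-fold higher number from compound 1 to compound 4 (1.30 log units; beyond the scatter), an at least 11-fold higher number from compound 3 to compound 4 (1.04 log units; beyond the scatter) and an at least 9.2-fold higher number from compound 2 to compound 4 (0.96 log units; beyond the scatter). The size of the step from hexyl therefore depends on which aromatic ring enters: compounds 2 and 3 lie within the scatter of each other, and compound 4 lies clear of both.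

Going by these compounds, how much of this step belongs to the ring nitrogen stays open, as does its true size, since one end of it is a limit. On these data alone, how a plain phenyl ring, a chain ending in an amine or a chain longer than hexyl would stand at this place is also open.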